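From a methyltetrazole to a methyloxazole in compound 4

The source may report more compounds than this note shows. Statements on the series, on what has been measured and on what is new or still open speak of the compounds shown alone.

Of the compounds shown here, three sharing one core have been measured in a functional assay on Jurkat cells for inhibition of nuclear factor NF-kappa-B complex (Homo sapiens); on this read-out lower numbers stand for stronger inhibition and higher numbers for weaker inhibition. Compound 1 `CCOC(=O)c1cnc(-c2cccs2)nc1NN1C(=O)C=C(C)C1=O` gives 20 nM. Compound 2 `CC1=CC(=O)N(Nc2nc(-c3cccs3)ncc2C#N)C1=O` gives 5000 nM. Compound 3 `CC1=CC(=O)N(Nc2nc(-c3cccs3)ncc2-c2nnn(C)n2)C1=O` gives 200 nM, which places it second highest of the three numbers, with a 10-fold higher number from compound 1 to compound 3 (1.00 log units; beyond the scatter) and a 25-fold lower number from compound 2 to compound 3 (1.40 log units; beyond the scatter). Compound 4 `CC1=CC(=O)N(Nc2nc(-c3cccs3)ncc2-c2nc(C)co2)C1=O` has not yet been measured; it differs from compound 3 in that (4-methyl-1,3-oxazol-2-yl in place of 2-methyl-2H-tetrazol-5-yl on an aromatic carbon).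

Within the data shown here, no measured step swaps one five-membered aromatic ring for another at this position, so the case is only partly covered. The steps of a 250-fold higher number from compound 1 to compound 2 (2.40 log units; beyond the scatter) and a 25-fold lower number from compound 2 to compound 3 (1.40 log units; beyond the scatter) show that the group on this carbon moves the number a great deal, while a 10-fold higher number from compound 1 to compound 3 (1.00 log units; beyond the scatter) shows the tetrazole already sits well away from the ester. Since a five-membered aromatic ring remains in place, compound 4 is expected to stay near compound 3, and the step of a 1.3-fold higher number from compound 3 to compound 4 (0.10 log units; within the scatter) is estimated as modest in either direction, with wide uncertainty. Compound 4 is therefore estimated at 250 nM, in a range from 50 nM to 1500 nM.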

Compound 4, half-maximal inhibitory concentration: 200 nM
For compound 4 the middle estimate is 1.3-fold (0.10 log units) above the measured one; measured number inside the range.
By their numbers in this assay, from the lowest: compound 1; then compounds 3 and 4 (each within the scatter of the next); then compound 2.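

In this assay the swap of 2-methyl-2H-tetrazol-5-yl for 4-methyl-1,3-oxazol-2-yl gives no change at the digits printed from compound 3 to compound 4 (within the scatter), so at this aromatic carbon a five-membered aromatic ring with 2 hetero atoms reads the same as one with 4, and the drop from 4 hydrogen-bond acceptors to 2 leaves the number in place. The oxazole also takes the tetrazole's standing against the other two groups, with a 25-fold lower number from compound 2 to compound 4 (1.40 log units; beyond the scatter) and a 10-fold higher number from compound 1 to compound 4 (1.00 log units; beyond the scatter), so the tetrazole's place in the order is not particular to that ring. Nothing measured here explains why the two rings read alike.

The compounds shown leave open whether a phenyl ring or an oxazole without its methyl would hold this level. They also leave open how a carboxylic acid or a longer ester chain on this carbon would compare with compound 1.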